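A few compounds are considered here, and "the series" means these few. Any claim that something is new, unique, unknown or untested is made for them only; others in the source may bear on it.

Going by the values given here, in a functional assay on HeLa cells (Homo sapiens) for antiproliferative activity, read by sulforhodamine B assay (on this read-out lower numbers stand for stronger inhibition of growth and higher numbers for weaker inhibition of growth), compound 3 (`C=CC[C@@H]1O[C@H](COCc2ccccc2)[C@@H](OCc2ccccc2)[C@H](OCc2ccccc2)[C@H]1O`) gives 26200 nM, the only actual number so far. Compound 4 (`C=CC[C@@H]1O[C@H](COCc2ccccc2)[C@@H](OCc2ccccc2)[C@H](OCc2ccccc2)[C@H]1OC(C)=O`) differs from it by acetyl in place of hydrogen on an oxygen on a saturated carbon, hydroxy to acetoxy. Compound 1 (`CC(=O)O[C@@H]1[C@@H](OCc2ccccc2)[C@H](OCc2ccccc2)[C@@H](COCc2ccccc2)O[C@H]1C`), which carries acetoxy, gives > 50000 nM, a limit of the assay. Compound 2 (`CC[C@@H]1O[C@H](COCc2ccccc2)[C@@H](OCc2ccccc2)[C@H](OCc2ccccc2)[C@H]1OC(C)=O`), also with acetoxy, gives > 50000 nM, likewise a limit. Among the compounds with values here, the one measured step, a step that the two limits leave unreadable from compound 1 to compound 2, offers no size to carry over. The nearest guide is therefore (the limit of > 50000 nM in this assay, at which 2 of the 3 values shown sit), and it points toward weaker inhibition of growth, of modest size. The expected change is a 1.8-fold higher number from compound 3 to compound 4 (0.26 log units; within the scatter). For compound 4 the estimated value is 48000 nM, in an expected range of 22000 nM to 100000 nM.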

Compound 4, concentration for 50% growth inhibition: > 50000 nM
Compound 4: only a limit was reported (the forecaster's own chance of this, stated with the estimate: 60%); middle value at least 1.0-fold (0.01 log units) away from the limit.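

The hydroxy to acetoxy change can now be read directly for the first time, as an at least 1.9-fold higher number from compound 3 to compound 4 (0.28 log units; that floor lies within the scatter); only a floor is known, so a real loss is neither shown nor excluded. The steps from compound 1 and from compound 2 to compound 4 cannot be read, so nothing can be said about the chain while the acetoxy is present: the limit of > 50000 nM in this assay, at which 3 of the 4 values shown sit.

Still open, on these data alone, is whether the hydroxy gives a number with the chains of compound 1 and compound 2. Also open, as far as these compounds go, is what an amine or a carboxylic acid in place of the hydroxy would give.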